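Replacing 4-hydroxybutyl with 3,4-dihydroxyphenyl on a saturated chain

This account rests on a few compounds, and the source may have more. Where it says the series, first, only, none or still open, it means among the compounds named here.

- In an ADME assay on MRC5 cells (Homo sapiens) for inhibition, read by MTT assay, with a stated time of 72 h (on this read-out higher numbers stand for weaker inhibition and lower numbers for stronger inhibition), compound 1 `O=C(OCCCCCCO)OCCc1ccc(O)c(O)c1` gives > 50000 nM
- In this assay compound 2 `O=C(OCCc1ccc(OCc2ccccc2)c(OCc2ccccc2)c1)OCCc1ccc(OCc2ccccc2)c(OCc2ccccc2)c1` gives "not determined" (no result reported)

Compound 1 stands at > 50000 nM in this assay, and this is a limit of the assay, not a number. Compound 2 gives no result to compare with it. Compound 3 `O=C(OCCc1ccc(O)c(O)c1)OCCc1ccc(O)c(O)c1` has yet to be measured. It carries 3,4-dihydroxyphenyl in place of 4-hydroxybutyl on a saturated chain carbon, two bonds along the chain from an oxygen next to a carbonyl group, as counted in 3,4-dihydroxyphenyl in place of 4-hydroxybutyl on a saturated chain carbon, two bonds along the chain from an oxygen next to a carbonyl group. No measured pair sizes such a change. In this assay only a small shift toward stronger inhibition is expected, or none beyond the scatter, and the estimated move is an at least 1.1-fold lower number from compound 1 to compound 3 (0.04 log units; that floor lies within the scatter). Compound 3 is estimated at 45000 nM (range 15000 nM to 100000 nM).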

Compound 3, half-maximal inhibitory concentration: > 50000 nM
Compound 3 was reported as a limit; the forecaster's own chance of this, stated with the estimate: 60%; at least 1.1-fold (0.04 log units) between middle value and limit.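

No step from compound 1 to compound 3 can be read in this assay, because both values are limits of the assay and not numbers: the limit of > 50000 nM in this assay, at which 2 of the 3 values shown sit.

The compounds shown leave open how large a shift, if any, 3,4-dihydroxyphenyl in place of 4-hydroxybutyl brings in this assay.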